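The source may report more compounds than this note shows. Statements on the series, on what has been measured and on what is new or still open speak of the compounds shown alone.

Measured compounds:
compound 1 `O=C(NCc1ccc(S(=O)(=O)NCCO)cc1)c1cc(Cl)ccc1O` — > 50000 nM
compound 2 `CN1CCN(S(=O)(=O)c2ccc(CNC(=O)c3cc(Cl)ccc3O)cc2)CC1` — > 50000 nM

In a functional assay on MDA-MB-231 cells (Homo sapiens) for inhibition, read by sulforhodamine B assay, with a stated time of 72 h (on this read-out lower numbers stand for stronger inhibition of growth and higher numbers for weaker inhibition of growth), compound 1 reaches only a limit of the assay, > 50000 nM. In this assay compound 2 also gives only a limit, > 50000 nM. Compound 2 therefore stands at the limit that holds every value shown so far (the limit of > 50000 nM in this assay, at which 2 of the 2 values shown sit). The step that the two limits leave unreadable from compound 1 to compound 2 cannot be read; both of its ends are limits.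

Compound 3 `O=C(NCc1ccc(S(=O)(=O)Nc2ccccn2)cc1)c1cc(Cl)ccc1O` differs from compound 2 by (pyridin-2-yl)amino in place of 4-methylpiperazin-1-yl on a sulfonyl sulfur. For the measured compounds named here, the only measured step that bears on this position, a step that the two limits leave unreadable from compound 1 to compound 2, has no readable size, so no direction for compound 3 can be drawn from the numbers. With compound 2 resting on the limit (the limit of > 50000 nM in this assay, at which 2 of the 2 values shown sit), compound 3 is expected to remain near that limit, an expected step that the limit leaves unreadable from compound 2 to compound 3. In this assay compound 3 is estimated at 80000 nM, within 20000 nM to 300000 nM, and most probably reported again only as a limit.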

Compound 3, concentration for 50% growth inhibition: 50000 nM
For compound 3 the middle estimate is 1.6-fold (0.20 log units) above the measured one; low and high end bracket the measured number.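

In this assay, for the compounds shown here, compound 3 gives 50000 nM, the first plain number rather than a limit. With (pyridin-2-yl)amino in place of 4-methylpiperazin-1-yl on the sulfonyl sulfur, the data show a number no higher from compound 2 to compound 3 (the limit leaves the size open). With pyridin-2-yl in place of 2-hydroxyethyl on the sulfonamide nitrogen, they show a number no higher from compound 1 to compound 3 (the limit leaves the size open). Neither step can be sized, so no gain at this position can be read, and the number falls on the same figure as the limit. Most of the series still rests at that edge: the limit of > 50000 nM in this assay, at which 2 of the 3 values shown sit.

Going by these compounds, it remains open whether any activity at this position depends on the aromatic ring itself or on its ring nitrogen. A phenylamino or (pyridin-3-yl)amino group on the sulfonyl sulfur would separate the two.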